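Phenethyl in Place of Naphthalen-2-yl at the Ring Nitrogen Chain

The source may hold more compounds than are shown below. What is called first, only, known or untested is meant among the compounds shown, and "the series" means these compounds.

Of the compounds shown here, three sharing one core have been measured in an assay on COS-7 cells for inhibition of sodium/nucleoside cotransporter 2 (Homo sapiens), read by scintillation counting, in the presence of a further agent that is not named here; on this read-out higher numbers stand for weaker inhibition and lower numbers for stronger inhibition. Compound 1 `Cc1cccc(CNc2nc3c(N)ncnc3n2[C@@H]2O[C@H](CO)[C@@H](O)[C@H]2O)c1` gives 19000 nM. Compound 2 `Nc1ncnc2c1nc(NCc1ccccc1Cl)n2[C@@H]1O[C@H](CO)[C@@H](O)[C@H]1O` gives 5700 nM, and compound 3 `Nc1ncnc2c1nc(NCc1ccc3ccccc3c1)n2[C@@H]1O[C@H](CO)[C@@H](O)[C@H]1O` gives 5300 nM. Among these three numbers compound 3 stands lowest, though the step of a 1.1-fold lower number from compound 2 to compound 3 (0.03 log units; within the scatter) lies within the scatter, so those two cannot be ordered; the step of a 3.6-fold lower number from compound 1 to compound 3 (0.55 log units; beyond the scatter) is clear.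

Compound 4 `Nc1ncnc2c1nc(NCCCc1ccccc1)n2[C@@H]1O[C@H](CO)[C@@H](O)[C@H]1O` is the next case, not yet measured. The change from compound 3 is phenethyl in place of naphthalen-2-yl on a saturated chain carbon bound to a nitrogen on an aromatic ring. The step that bears on it most is a 3.6-fold lower number from compound 1 to compound 3 (0.55 log units; beyond the scatter), where a single six-membered aromatic ring of carbon only, with a methyl, gave the higher number and naphthalen-2-yl the lower one. The step of a 1.1-fold lower number from compound 2 to compound 3 (0.03 log units; within the scatter) shows that not every single-ring group sits higher than naphthalen-2-yl. For the measured compounds named here, no measured step covers a phenethyl chain on this carbon, so the effect of the longer chain is unknown. The author therefore expects a modest rise in this assay, a 2.3-fold higher number from compound 3 to compound 4 (0.35 log units; beyond the scatter), with wide uncertainty. Compound 4 is estimated at 12000 nM, with a range from 4000 nM to 36000 nM.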

Compound 4, half-maximal inhibitory concentration: 536000 nM
Compound 4: the middle estimate sits 45-fold (1.65 log units) below what was measured; measured number above the stated range.
By their numbers in this assay, from the lowest: compounds 3 and 2 (each within the scatter of the next); then compound 1; then compound 4.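

In this assay the steps to compound 4 are all large, namely a 100-fold higher number from compound 3 to compound 4 (2.00 log units; beyond the scatter) and a 94-fold higher number from compound 2 to compound 4 (1.97 log units; beyond the scatter) and a 28-fold higher number from compound 1 to compound 4 (1.45 log units; beyond the scatter) at this one place, on a saturated chain carbon bound to a nitrogen on an aromatic ring, whereas the earlier changes there gave modest steps at most. Compound 4 carries one six-membered aromatic ring of carbon only, as compound 1 and compound 2 also do, so the count of such rings does not by itself separate compound 4 from the other two, and phenethyl is the one group shown here that gives a large rise in the number. Nothing in the material at hand explains why phenethyl gives so much higher a number than the other groups.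

The compounds shown leave open whether the rise follows the chain itself or the way the ring is held on it, since no intermediate group, such as a phenethyl chain with a methyl or chlorine on its ring, stands among them. They also leave open whether an amine or a carboxylic acid on such a chain would lower the number again.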